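The source may hold more compounds than are shown below. What is called first, only, known or untested is meant among the compounds shown, and "the series" means these compounds.

Among the compounds with values here, compound 2, with the structure `CCCCN(Cc1ccc(OCCN2C(=O)CCC2=O)c(C)c1)C(CC(=O)O)c1ccc(Cl)cc1`, holds the lowest of the two numbers so far: in an assay on CHO cells for displacement of a labelled ligand from C-X-C chemokine receptor type 3 (Homo sapiens), with a stated time of 60 min (on this read-out higher numbers stand for weaker inhibition and lower numbers for stronger inhibition), compound 2 gives 61 nM. Within the data shown here, its only neighbour is compound 1, whose structure `CCN(Cc1ccc(OCCN2C(=O)CCC2=O)c(C)c1)C(CC(=O)O)c1ccc(Cl)cc1` differs from it at one place; in this assay compound 1 gives 424 nM, and the step of a 7.0-fold lower number from compound 1 to compound 2 (0.84 log units; beyond the scatter) shows that lengthening the chain on the amine nitrogen paid off clearly. Compound 3, with the structure `Cc1cc(CN(CC2CCCC2)C(CC(=O)O)c2ccc(Cl)cc2)ccc1OCCN1C(=O)CCC1=O`, carries the change (cyclopentyl in place of propyl on a saturated chain carbon bound to an amine nitrogen). Among the measured compounds shown here, the measured step bears on it only indirectly, as it grew a chain at this same nitrogen, whereas here the chain closes into a ring of comparable extent; no measured pair speaks to a ring at this spot. A step within the scatter, or at most a slight move toward a lower number, is therefore expected, a 1.5-fold lower number from compound 2 to compound 3 (0.18 log units; within the scatter). Compound 3 is expected to give about 40 nM in this assay, within the range 15 nM to 120 nM.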

Compound 3, half-maximal inhibitory concentration: 71 nM
The estimate for compound 3 lay 1.8-fold (0.25 log units) below the measured number; low and high end bracket the measured number.
By their numbers in this assay, from the lowest: compounds 2 and 3 (each within the scatter of the next); then compound 1.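

In this assay, closing the chain into a ring makes no difference that can be told apart, with a 1.2-fold higher number from compound 2 to compound 3 (0.07 log units; within the scatter), so this place on the amine nitrogen accepts cyclopentyl as readily as the open chain of compound 2. The gain over the shorter chain also survives the ring, with a 6.0-fold lower number from compound 1 to compound 3 (0.78 log units; beyond the scatter), which shows that the earlier improvement is not tied to an open chain. No measurement at hand accounts for the ring and the open chain scoring alike.

The compounds shown leave open how far this place stretches, and whether a cyclohexyl ring or a longer chain such as pentyl would hold the number or lose it. They also leave open whether an ether oxygen or an amine within the ring would be accepted.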